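Changing one group on a potent compound

The compounds below may be only part of what the source reports. "The series", "measured", "known", "first", "only" and "open" are said of these compounds alone.

Measured in a functional assay with Oryctolagus cuniculus as the target; on this read-out lower numbers stand for stronger inhibition and higher numbers for weaker inhibition:
- compound 1 `COc1ccc(-c2nc(N=C(N)N)sc2-c2ccc(OC)cc2)cc1`: 31000 nM
- compound 2 `COc1ccc(-c2nc(/N=C(\N)N(C)C)sc2-c2ccc(OC)cc2)cc1`: 37 nM
- compound 3 `COc1ccc(-c2nc(C(=O)N(C)C)sc2-c2ccc(OC)cc2)cc1`: < 100 nM (a limit)

Compound 3 is reported only as a limit, < 100 nM, in this assay. The next compound, compound 4 `COc1ccc(-c2nc(/C=C/C(=O)O)sc2-c2ccc(OC)cc2)cc1`, keeps the shared core and differs in one group: 2-carboxyethenyl in place of dimethylcarbamoyl on an aromatic carbon. In words, 2-carboxyethenyl takes the place of dimethylcarbamoyl on the aromatic carbon.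

The measured steps all concern this same kind of swap, and they show that the choice of group can matter a great deal. The data give an 840-fold lower number from compound 1 to compound 2 (2.92 log units; beyond the scatter) and also an at least 310-fold lower number from compound 1 to compound 3 (2.49 log units; beyond the scatter). There is also a step that the limit leaves unreadable from compound 2 to compound 3. Compound 1, at 31000 nM, shows how high the number can climb with another group in this place. Among the compounds with values here, none of the measured compounds carries 2-carboxyethenyl, so no step carries over directly and the uncertainty is wide. A clearly higher number in this assay, meaning weaker inhibition, is the expected direction, though a smaller change remains possible. The expected change is an at least 6.0-fold higher number from compound 3 to compound 4 (0.77 log units; beyond the scatter). For compound 4 the estimated value is 600 nM, with an expected range from 40 nM to 10000 nM.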

Compound 4, half-maximal inhibitory concentration: > 100 nM
Compound 4 ended at the assay's limit; the forecaster's own chance of this, stated with the estimate: 15%; the middle value does not contradict the limit.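

Compound 4 is reported only as a limit, > 100 nM, in this assay. The swap of dimethylcarbamoyl for 2-carboxyethenyl gives a number no lower from compound 3 to compound 4 (the limit leaves the size open). Even so, placing 2-carboxyethenyl on this aromatic carbon, next to the ring nitrogen and next to the ring sulfur, gives an at least 2.7-fold higher number from compound 2 to compound 4 (0.43 log units; beyond the scatter), which shows that a group holding carbon and oxygen but no nitrogen does not match compound 2 in this place. The step from compound 1 to compound 4 cannot be read, because the result for compound 4 gives only this: the limit of > 100 nM in this assay, at which 1 of the 4 values shown sits.

The compounds shown leave open where compound 4 truly lies, whether close to compound 3 or as high as compound 1, and so whether the swap of dimethylcarbamoyl for 2-carboxyethenyl costs little or a great deal. They also leave open which part of the new group matters, the carboxylic acid end or the two-carbon chain with its double bond that carries it, a question that a plain carboxylic acid on the same carbon, or a dimethylamide at the end of the same chain, would bear on.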